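The source may report more compounds than this note shows. Statements on the series, on what has been measured and on what is new or still open speak of the compounds shown alone.

Compound 1, `O=C(Nc1ncc(Cc2ccc(F)cc2)s1)c1ccc(Br)cc1`, was tested in an ADME assay on HepG2 2.2.15 cells (Homo sapiens) for cytotoxicity; a higher number here means that more compound is tolerated, a lower number that less compound is tolerated. In that test compound 1 reached only a limit of the assay, > 50000 nM. Compound 2, `COCCCNc1ncc(C(Oc2ccc3cc(Br)ccc3c2)c2ccc(Cl)cc2)s1`, is described in this assay as "not toxic" (no number reported), without a single number. Of the two results available, one sits at the limit of > 50000 nM in this assay, at which 1 of the 2 values shown sits; compound 2 stands beside it with a verbal report only, so neither compound offers a figure that could be ranked against another. Compound 3, `N#Cc1cccc(C(=O)Nc2ncc(C(Oc3ccc4cc(Br)ccc4c3)c3ccc(Cl)cc3)s2)c1`, is the compound not yet measured. It differs from compound 2 in one place: (3-cyanophenyl)carbonyl in place of 3-methoxypropyl on a nitrogen on an aromatic ring. Going by the values given here, no step between two measured compounds exists to calibrate this change, so any expectation rests on the two compounds alone, both of which were tolerated as far as the assay could read. In this assay the move from compound 2 to compound 3 is expected to bring no shift beyond the scatter, in no particular direction. Compound 3 is therefore estimated at 50000 nM, within a range of 15000 nM to 100000 nM, and most likely again reported only as a limit.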

Compound 3, half-maximal cytotoxic concentration: > 50000 nM
Compound 3 gave a limit, no number; the forecaster's own chance of this, stated with the estimate: 65%; the middle value lies on the limit itself.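

Going by these compounds alone, compound 3 gave only a limit of the assay and compound 2 only a verbal report, so no step from compound 2 to compound 3 can be read. The compounds shown leave open what concentration of any of them would actually harm the cells, as the numerical results stop at one limit: the limit of > 50000 nM in this assay, at which 2 of the 3 values shown sit.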